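Amide aryl variation on a long-chain threonine scaffold

The source may report more compounds than this note shows. Statements on the series, on what has been measured and on what is new or still open speak of the compounds shown alone.

Compounds measured in a functional assay on SiHa cells (Homo sapiens) for cytotoxicity, read by MTT assay, with a stated time of 48 h; a lower number here means a stronger inhibitor, a higher number a weaker inhibitor:
compound 1 `CCCCCCCCCCCCCCCCCCNC(=O)[C@@H](NC(=O)c1ccccc1)[C@@H](C)O`, 38200 nM
compound 2 `CCCCCCCCCCCCCCCCCCNC(=O)[C@@H](NC(=O)c1ccco1)[C@@H](C)O`, 13400 nM
compound 3 `CCCCCCCCCCCCCCCCCCNC(=O)[C@@H](NC(=O)c1cccs1)[C@@H](C)O`, 117000 nM

All three share the shared core and differ only in the group on the carbonyl carbon of the amide. Compound 3 gives the highest number of the three in this assay; its nearest neighbour is compound 1 and its furthest is compound 2, and both gaps lie beyond the scatter.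

Compound 4 `CCCCCCCCCCCCCCCCCCNC(=O)[C@@H](NC(=O)c1nccc2ccccc12)[C@@H](C)O` is not yet measured. It differs from compound 3 as follows: isoquinolin-1-yl in place of thiophen-2-yl on a carbonyl carbon.

Among the measured compounds shown here, the steps that bear on this are the three swaps of the aryl group on that same carbonyl carbon: a 2.9-fold lower number from compound 1 to compound 2 (0.45 log units; beyond the scatter), a 3.1-fold higher number from compound 1 to compound 3 (0.49 log units; beyond the scatter) and an 8.7-fold higher number from compound 2 to compound 3 (0.94 log units; beyond the scatter). Each of these is modest, and the whole spread of the series stays within a narrow band. No bicyclic group has been tried, so the direction for compound 4 is uncertain. Since compound 3 already gives the highest number, and the other two aryl groups gave lower numbers, a moderate fall is expected: a 3.3-fold lower number from compound 3 to compound 4 (0.52 log units; beyond the scatter).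

Compound 4 is estimated at 35000 nM, with a range from 8000 nM to 150000 nM.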

Compound 4, half-maximal inhibitory concentration: 51200 nM
Compound 4: the middle estimate sits 1.5-fold (0.17 log units) below what was measured, within the range that was stated.
By their numbers in this assay, from the lowest: compound 2; then compounds 1 and 4 (each within the scatter of the next); then compound 3.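

In this assay the carbonyl carbon of the amide carries a two-ring group, isoquinolin-1-yl, in compound 4, and the number stays inside the band set by the single-ring groups of compound 2 and compound 3 (a 2.3-fold lower number from compound 3 to compound 4 (0.36 log units; beyond the scatter); a 3.8-fold higher number from compound 2 to compound 4 (0.58 log units; beyond the scatter)). Against phenyl the change gives no readable shift (a 1.3-fold higher number from compound 1 to compound 4 (0.13 log units; within the scatter)), so the second aromatic ring separates compound 4 from compound 1 by no more than the usual scatter. Ring count alone therefore does not order these four compounds: the two five-membered groups, furan-2-yl and thiophen-2-yl, fall on opposite sides of compound 1 and compound 4.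

Going by these compounds, whether an amine or a carboxylic acid on the isoquinolin-1-yl group, or a shorter chain in place of the long chain, would move these numbers stays open. Nothing in the data at hand gives a cause for these steps.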